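A few compounds are considered here, and "the series" means these few. Any claim that something is new, unique, unknown or untested is made for them only; others in the source may bear on it.

Of the compounds shown here, two built on a shared core have been measured so far, and they differ in the aromatic groups at the two ends of that core. Compound 1 `O=C(NCc1ccc(CNS(=O)(=O)c2ccccc2)cc1)c1ccccc1Cl` is tested in an assay on MDA-MB-231 cells for binding affinity to C-X-C chemokine receptor type 4 (Homo sapiens), read by immunofluorescence and microscopy, with stated times of 10 min and 30 min (a higher number here means that more compound is needed for the effect, a lower number that less compound is needed), and gives 10 nM. Compound 2 `Cc1ccc(S(=O)(=O)NCc2ccc(CNC(=O)c3ccccc3C)cc2)cc1` gives 100 nM in this assay, a higher number than compound 1, so of the two compounds measured, compound 1 stands at the lower number. Compound 3 `COc1cccc(C(=O)NCc2ccc(CNS(=O)(=O)c3ccccc3)cc2)c1` has not yet been measured. It differs from compound 1 in one place: 3-methoxyphenyl in place of 2-chlorophenyl on a carbonyl carbon. Going by the values given here, no measured pair differs in only one place, so there is no direct precedent for this change within these data. Compound 3 is expected to need somewhat more compound than compound 1, a step of a 4.0-fold higher number from compound 1 to compound 3 (0.60 log units; beyond the scatter) that may reach beyond the usual scatter. The estimate for compound 3 is 40 nM, with a range from 10 nM to 160 nM.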

Compound 3, effective concentration (reported as EC, without a stated level of effect): > 1000 nM
Compound 3 gave a limit, no number; the forecaster's own chance of this, stated with the estimate: 5%; at least 25-fold (1.39 log units) between middle value and limit.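

Going by these compounds alone, this is the first change that can be read on its own: 3-methoxyphenyl in place of 2-chlorophenyl on a carbonyl carbon gives an at least 100-fold higher number from compound 1 to compound 3 (2.00 log units; beyond the scatter), a large step. In this assay compound 3 gives > 1000 nM, which is a limit and not a number. This place on the core of compound 1 is therefore not free to take just any aromatic group, and only one compound so far stands at this limit: the limit of > 1000 nM in this assay, at which 1 of the 3 values shown sits.

The compounds shown cannot separate the loss of the chlorine from the arrival of the methoxy group, or either of these from where each group sits on the ring. A plain phenyl group on that carbonyl carbon, carrying neither chlorine nor methoxy, would be a useful next comparison.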